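The source may hold more compounds than are shown below. What is called first, only, known or untested is meant among the compounds shown, and "the series" means these compounds.

Measured compounds:
- compound 1 `Cc1csc(NC(=O)c2cccc3[nH]c(-c4ccccn4)nc23)n1`: 17.7 uM
- compound 2 `COc1ccc(-c2nc3c(C(=O)NCCCO)cccc3[nH]2)cc1OC`: 46 uM
- compound 3 `COc1ccc(-c2nc3c(C(=O)NCCCO)cccc3[nH]2)c(OC)c1OC`: 40 uM

In an ADME assay on Vero cells (Chlorocebus sabaeus) for cytotoxicity (a higher number here means that more compound is tolerated, a lower number that less compound is tolerated), compound 2 stands highest of the three numbers, but its nearest neighbour is compound 3, and the step of a 1.2-fold lower number from compound 2 to compound 3 (0.06 log units; within the scatter) is too small to count as a real difference. Compound 1 sits further away, with a number beyond the scatter below that of compound 2, yet compound 1 and compound 2 differ in more than one place, so no single step can be read from that pair.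

Compound 4 `COc1ccc(-c2nc3c(C(=O)Nc4nc(C#N)c(C#N)[nH]4)cccc3[nH]2)cc1OC` has not yet been measured. It differs from compound 2 by 4,5-dicyano-1H-imidazol-2-yl in place of 3-hydroxypropyl on an amide-type nitrogen. Among the measured compounds shown here, none of the measured steps covers a change of this kind: the only step available, from compound 2 to compound 3, concerns a methoxy on an aromatic carbon and stays within the scatter, and it says nothing about swapping the group on the amide-type nitrogen. For the measured compounds named here, the two values of compound 1 and compound 2 show only that a compound carrying an aromatic group on that nitrogen gave a lower number, without isolating the cause.

On this thin basis, compound 4 is expected to give a somewhat lower number than compound 2, with wide uncertainty: the estimated step is a 1.8-fold lower number from compound 2 to compound 4 (0.26 log units; within the scatter). The estimate for compound 4 in this assay is 25 uM, expected to lie between 8 uM and 70 uM.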

Compound 4, half-maximal toxic concentration: 43.1 uM
The estimate for compound 4 lay 1.7-fold (0.24 log units) below the measured number; measured number inside the range.
By their numbers in this assay, from the lowest: compound 1; then compounds 3, 4 and 2 (each within the scatter of the next).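

Among the compounds shown here, replacing the group on the amide-type nitrogen gives the first single-place step at this position in this assay (a 1.1-fold lower number from compound 2 to compound 4 (0.03 log units; within the scatter)), whereas the earlier step concerned only a methoxy on an aromatic carbon. The step shows that, in this pair, the open 3-hydroxypropyl chain can be exchanged for 4,5-dicyano-1H-imidazol-2-yl, which brings in a five-membered aromatic ring and two nitriles, without the cell tolerance moving beyond the scatter. Nothing available explains why the two compounds read alike.

A single pair cannot show whether this holds for other groups on the same nitrogen, such as a plain phenyl ring, a chain ending in an amine or a chain ending in a carboxylic acid. It also leaves open how the unsubstituted imidazol-2-yl group, without either nitrile, would compare, so the ring and the nitriles cannot yet be judged separately on this nitrogen.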